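From Compound 2 to Compound 4: an Expected Potency

This account rests on a few compounds, and the source may have more. Where it says the series, first, only, none or still open, it means among the compounds named here.

Measured compounds:
Compound 1, `CCCNCc1cc(-c2c(C(=O)NCC)noc2-c2cc(C(C)C)c(O)cc2O)on1`: "not determined" (no result reported) in a functional assay on A2780 cells (Homo sapiens) for inhibition; a lower number here means a stronger inhibitor, a higher number a weaker inhibitor.
Compound 2, `CCNC(=O)c1noc(-c2cc(C(C)C)c(O)cc2O)c1-c1cc(CNC(C)=O)no1`: "not determined" (no result reported).
Compound 3, `CCNC(=O)c1noc(-c2cc(C(C)C)c(O)cc2O)c1-c1cc(CN2CCCCC2)no1`: 62 nM.

Compound 2 stands without a single number in this assay, and compound 1 likewise has none, so only compound 3, with 62 nM, gives the series an anchor. Compound 4, `CCNC(=O)c1cc(-c2c(C(=O)NCC)noc2-c2cc(C(C)C)c(O)cc2O)on1`, differs from compound 2 by ethylcarbamoyl in place of acetamidomethyl on an aromatic carbon. Going by the values given here, no measured pair shows this change on its own, so the size of the step in this assay cannot be read from the data; a shift beyond the usual scatter in either direction would not be surprising, and neither direction is favoured. Compound 4 is expected to give about 300 nM, within a range of 50 nM to 2000 nM.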

Compound 4, half-maximal inhibitory concentration: 43 nM
Compound 4: middle estimate off by 7.0-fold (0.84 log units), on the high side; the measured number lies below the stated range.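

At this aromatic carbon, ethylcarbamoyl in place of (piperidin-1-yl)methyl gives a 1.4-fold lower number from compound 3 to compound 4 (0.16 log units; within the scatter) in this assay. This first readable comparison shows that the position can carry either of these two different groups with no difference beyond the scatter. No available measurement offers a reason for this match.

Steps involving compound 1 or compound 2 cannot be read, as neither compound has a single number. As far as these compounds go, it also remains open how a carboxylic acid, or a longer chain on the amide nitrogen, would behave at this position.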